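Halogen exchange at one aromatic carbon

A few compounds are considered here, and "the series" means these few. Any claim that something is new, unique, unknown or untested is made for them only; others in the source may bear on it.

Compound 1 `CC#CCn1c(N2CCC[C@@H](N)C2)cc(=O)n(Cc2ccc(Br)c(C(=O)OC)c2)c1=O` and compound 2 `CC#CCn1c(N2CCC[C@@H](N)C2)cc(=O)n(Cc2ccc(F)c(C(=O)OC)c2)c1=O` share one core and differ only in the halogen on an aromatic carbon. In an ADME assay on the whole organism (Rattus norvegicus, strain Sprague-Dawley) for pharmacokinetics, read by LC-MS, with a stated time of 48 h, at a dose of 10 mg/kg by the oral route (on this read-out higher numbers stand for higher exposure at the dose given and lower numbers for lower exposure), compound 1 gives 1380000 ng.h/mL and compound 2 gives 5880 ng.h/mL, so compound 2 holds the lower of the two numbers. Compound 3 `CC#CCn1c(N2CCC[C@@H](N)C2)cc(=O)n(Cc2ccc(Cl)c(C(=O)OC)c2)c1=O` keeps the shared core and changes one place: chloro in place of fluoro on an aromatic carbon, ortho to a methoxycarbonyl group. Within the data shown here, one measured step bears on this: a 230-fold lower number from compound 1 to compound 2 (2.37 log units; beyond the scatter), large and beyond the scatter, for fluoro in place of bromo at that same carbon. Among the measured compounds shown here, that is a single pair, so no trend can be claimed, and no chloro compound has been measured. With compound 1 at 1380000 ng.h/mL as the only reference without fluoro, a higher number than that of compound 2 is expected in this assay, though short of the full size of that step. The expected change is a 10-fold higher number from compound 2 to compound 3 (1.01 log units; beyond the scatter), beyond the scatter. Compound 3 is estimated at 60000 ng.h/mL, with an expected range of 8000 ng.h/mL to 700000 ng.h/mL.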

Compound 3, area under the concentration-time curve: 26800 ng.h/mL
Compound 3: middle estimate off by 2.2-fold (0.35 log units), on the high side; the range from low to high includes it.
By their numbers in this assay, from the lowest: compound 2; then compound 3; then compound 1.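

With a third halogen on this aromatic carbon, the position reads as a graded series rather than a single pair: in this assay the exchange of fluoro for chloro gives a 4.6-fold higher number from compound 2 to compound 3 (0.66 log units; beyond the scatter) and the exchange of bromo for chloro gives a 51-fold lower number from compound 1 to compound 3 (1.71 log units; beyond the scatter) in the same read-out. Across these three compounds the numbers therefore rise in the order fluoro, chloro, bromo, no listed compound goes against that order, and the larger part of the span lies between chloro and bromo, so chloro stands much nearer to fluoro than to bromo. Nothing at hand explains this order or the uneven spacing of the three halogens.

Going by these compounds, whether the order extends beyond the halogens remains open, since the effect of a hydrogen, a methyl group or a nitrile on this carbon is unknown. Also open, on these data alone, is whether the same order would hold with a carboxylic acid in place of the methoxycarbonyl group, or with a different amine in place of the aminopiperidine-bearing part of the shared core.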